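The source may hold more compounds than are shown below. What is called first, only, known or untested is meant among the compounds shown, and "the series" means these compounds.

Measured so far in a functional assay, with a stated time of 20 min; a higher number here means a weaker inhibitor, a lower number a stronger inhibitor:
- compound 1 `CSc1nc(-c2cccs2)c(C#N)c(=O)n1C`: 71 ug/mL
- compound 2 `CCOC(=O)c1cnn(-c2nc(-c3ccccc3Cl)c(C#N)c(=O)n2C)c1N`: 78 ug/mL

Compound 2 stands at the higher of the two numbers in this assay, but compound 1 with its 71 ug/mL sits within the scatter of it, so the two cannot be told apart. Compound 3 `CCOC(=O)c1cnn(-c2nc(-c3ccc(Cl)cc3)c(C#N)c(=O)n2C)c1N` differs from compound 2 only in one place: 4-chlorophenyl in place of 2-chlorophenyl on an aromatic carbon. For the measured compounds named here, no measured pair shows a change of this kind, so nothing here tells how it acts. The step of a 1.1-fold lower number from compound 2 to compound 3 (0.05 log units; within the scatter) is expected to stay within the scatter, in no particular direction. Compound 3 is therefore estimated at 70 ug/mL, with a range from 35 ug/mL to 150 ug/mL.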

Compound 3, half-maximal inhibitory concentration: 64 ug/mL
Beside the measured number, compound 3's estimate is 1.1-fold (0.04 log units) above it; the range from low to high includes it.
By their numbers in this assay, from the lowest: compounds 3, 1 and 2 (each within the scatter of the next).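

In this assay, putting 4-chlorophenyl in place of 2-chlorophenyl gives a 1.2-fold lower number from compound 2 to compound 3 (0.09 log units; within the scatter) so the two placements of chlorine on this phenyl group cannot be told apart. For the compounds shown here, the earlier compounds offered no pair differing in one place, so this is the only direct reading of this aromatic carbon, ortho to a cyano group, and it holds for this one pair alone.

Going by these compounds, whether an amine or a carboxylic acid on the phenyl group in place of chlorine would move the number stays open. Nothing measured here bears on the reason for this result.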